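Varying the ether chain on the isoflavone-type core

This account rests on a few compounds, and the source may have more. Where it says the series, first, only, none or still open, it means among the compounds named here.

Compounds measured in an assay (Cricetulus griseus) for inhibition of aldehyde dehydrogenase, mitochondrial (Homo sapiens); a lower number here means a stronger inhibitor, a higher number a weaker inhibitor:
compound 1 `O=C(O)COc1ccc(-c2coc3cc(OCC(=O)O)ccc3c2=O)cc1`, a limit in this assay: >> 9000 nM.
compound 2 `CCOC(=O)CCCCCOc1ccc2c(=O)c(-c3ccc(O)cc3)coc2c1`: 280 nM.
compound 3 `CCCCC(Oc1ccc2c(=O)c(-c3ccc(O)cc3)coc2c1)C(=O)OCC`: 4500 nM.

Compound 2 holds the lowest number among the two numbers that were obtained; the nearest is compound 3, whose value sits beyond the scatter above it. Compound 1 gives only a limit, which stands as the limit of >> 9000 nM in this assay, at which 1 of the 3 values shown sits.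

Compound 4 `CCCCCCCCCCCCOc1ccc2c(=O)c(-c3ccc(O)cc3)coc2c1` has not yet been measured in this assay. It differs from compound 2 in one place: heptyl in place of ethoxycarbonyl on a saturated chain carbon, five bonds along the chain from an oxygen on an aromatic ring. Put simply, heptyl in place of ethoxycarbonyl on a saturated chain carbon, five bonds along the chain from an oxygen on an aromatic ring. Going by the values given here, no two measured compounds differ in only this way, so no measured step guides the expectation directly; compound 2 and compound 3 differ at a different chain carbon and in chain shape, so their values are noted but not read as a step.

The ethoxycarbonyl group of compound 2 is replaced by a plain alkyl continuation; whether this costs or gains is open. The step from compound 2 to compound 4 is estimated at a 2.1-fold higher number from compound 2 to compound 4 (0.33 log units; beyond the scatter), a modest loss, inside or just beyond the scatter. Compound 4 is expected at about 600 nM, within 120 nM to 3000 nM.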

Compound 4, half-maximal inhibitory concentration: > 9000 nM
Compound 4: no number, only a limit (the forecaster's own chance of this, stated with the estimate: 10%); middle value at least 15-fold (1.17 log units) from the limit.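

In this assay, putting heptyl in place of ethoxycarbonyl on a saturated chain carbon, five bonds along the chain from an oxygen on an aromatic ring, gives an at least 32-fold higher number from compound 2 to compound 4 (1.50 log units; beyond the scatter), a large step and the first one that can be read at this position. It shows that the ethoxycarbonyl end of this chain cannot be exchanged for a plain alkyl continuation without a large loss, so a long chain on that oxygen does not by itself give the number of compound 2, which stands at 280 nM. Compound 4 gives only a limit, not a number, so the step has a lower bound and no measured size: the limit of > 9000 nM in this assay, at which 1 of the 4 values shown sits.

What the compounds shown leave open is which part of the ethoxycarbonyl group matters, the carbonyl or the ethyl end, and how far the loss really goes. An amide or a nitrile at the end of the same chain, or a shorter alkyl chain in the same place, would be needed to separate these readings.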